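A thiophene in place of phenyl on the amide chain

The source may hold more compounds than are shown below. What is called first, only, known or untested is meant among the compounds shown, and "the series" means these compounds.

Among the measured compounds shown here, in an ADME assay on MT4 cells (Homo sapiens) for cytotoxicity, read by MTT assay (a lower number here means that less compound is tolerated, a higher number that more compound is tolerated), compound 1 `Cc1cc(C)cc(S(=O)(=O)c2c(C(=O)NCc3ccccc3)[nH]c3ccc(Cl)cc23)c1` gives 38000 nM, the only exact number so far. Compound 2 `Cc1cccc(C)c1S(=O)(=O)c1c(C(=O)NCc2ccncc2)[nH]c2ccc(Cl)cc12` gives > 55000 nM, which is a limit of the assay and not a number. Compound 3 `Cc1cc(C)cc(S(=O)(=O)c2c(C(=O)NCc3cccs3)[nH]c3ccc(Cl)cc23)c1` keeps the core of compound 1 and changes one group: thiophen-2-yl in place of phenyl on a saturated chain carbon bound to an amide-type nitrogen. The swap puts thiophen-2-yl in place of phenyl on a saturated chain carbon bound to an amide-type nitrogen. For the measured compounds named here, no measured pair shows what this swap does, so no change beyond the usual scatter is expected in this assay. The expected step is a 1.1-fold lower number from compound 1 to compound 3 (0.04 log units; within the scatter). For compound 3 the estimated value is 35000 nM, within a range of 17000 nM to 65000 nM.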

Compound 3, half-maximal cytotoxic concentration: 54500 nM
The estimate for compound 3 lay 1.6-fold (0.19 log units) below the measured number; measured number inside the range.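

The swap of phenyl for thiophen-2-yl on this chain gives a 1.4-fold higher number from compound 1 to compound 3 (0.16 log units; within the scatter) in this assay. At this place on the amide chain, then, the five-membered sulfur ring and the six-membered carbon ring cannot be told apart in this measurement. Compound 3 also stands close to the end of the readable range, which leaves little room for any further rise to show: the limit of > 55000 nM in this assay, at which 1 of the 3 values shown sits.

Still open, as far as these compounds go, is whether an amine or a carboxylic acid on the ring would move the number. A longer chain between the amide nitrogen and the ring is equally untested among the compounds shown.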